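The compounds below may be only part of what the source reports. "The series", "measured", "known", "first", "only" and "open" are said of these compounds alone.

Measured in a functional assay on cells (Neutrophil, Homo sapiens) for inhibition, with a stated time of 10 min; a lower number here means a stronger inhibitor, a higher number a weaker inhibitor:
- compound 1 `CCOC(=O)c1cnn2c1N(C(=O)Nc1ccccc1)C(c1ccccc1)C2`: > 1000 nM (a limit)
- compound 2 `CCOC(=O)c1cnn2c1N(C(=O)Nc1ccc(F)cc1)C(c1ccccc1)C2`: > 1000 nM (a limit)
- compound 3 `CCOC(=O)c1cnn2c1N(C(=O)Nc1cccc3ccccc13)C(c1ccccc1)C2`: 206 nM

Compound 2 gives only a limit, > 1000 nM. Compound 4 `NC(=O)c1cnn2c1N(C(=O)Nc1ccc(F)cc1)C(c1ccccc1)C2` differs from it in one place, with amino in place of ethoxy on a carbonyl carbon. For the measured compounds named here, no measured step touches this place. The two readable steps, an at least 4.8-fold lower number from compound 1 to compound 3 (0.68 log units; beyond the scatter) and an at least 4.8-fold lower number from compound 2 to compound 3 (0.68 log units; beyond the scatter), change the group on an amide-type nitrogen, and a step that the two limits leave unreadable from compound 1 to compound 2 cannot be sized. No size can therefore be carried over, and no gain beyond the scatter is expected in this assay. The expected step is a step that the limit leaves unreadable from compound 2 to compound 4. The estimate for compound 4 is 2500 nM, within an expected range from 600 nM to 10000 nM.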

Compound 4, half-maximal inhibitory concentration: 484 nM
The estimate for compound 4 lay 5.2-fold (0.71 log units) above the measured number; measured number below the stated range.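

In this assay, for the compounds shown here, carbamoyl in place of ethoxycarbonyl on the carbonyl carbon gives an at least 2.0-fold lower number from compound 2 to compound 4 (0.31 log units; beyond the scatter), the first readable step at this position, which the earlier compounds all left as ethoxycarbonyl. The change thus lowers the number without altering the 4-fluorophenyl group on the amide-type nitrogen. Compound 2 gives only a limit, so the true size of the step stays unknown: the limit of > 1000 nM in this assay, at which 2 of the 4 values shown sit.

Going by these compounds, whether the change acts likewise with phenyl or naphthalen-1-yl on that nitrogen remains open. So does the effect of a carboxylic acid or a nitrile in place of ethoxycarbonyl.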